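Aryl swap at the pyrazole carbon: compound 4 from compound 1

This account rests on a few compounds, and the source may have more. Where it says the series, first, only, none or still open, it means among the compounds named here.

Measured so far:
compound 1 `COc1cc(-c2c(C)nn(-c3nc(-c4ccc(Cl)c(Cl)c4)c(SC(C)C)s3)c2C(=O)O)cc(C(F)(F)F)c1` — 1380 nM
compound 2 `Cc1c(-c2cc(Cl)cc(Cl)c2)c(C(=O)O)nn1-c1nc(-c2cc(Cl)ccc2F)c(SC(C)C)s1` — 4800 nM
compound 3 `Cc1ccccc1-c1c(C)nn(-c2nc(-c3ccc(Cl)c(Cl)c3)c(SC(C)C)s2)c1C(=O)O` — 5500 nM

The read-out throughout is a functional assay on BJAB cells (Homo sapiens) for antiproliferative activity, with a stated time of 4 days; on this read-out lower numbers stand for an effect already at smaller amounts and higher numbers for an effect only at larger amounts of compound. Compound 1 gives the lowest of the three numbers; compound 2 sits a step beyond the scatter above it, and compound 3 sits furthest, also beyond the scatter. Compound 2 differs from compound 1 in two places, so only the two values can be set side by side.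

The next compound, compound 4 `COc1cncc(-c2c(C)nn(-c3nc(-c4ccc(Cl)c(Cl)c4)c(SC(C)C)s3)c2C(=O)O)c1`, keeps the shared core of compound 1 and changes one group: 5-methoxypyridin-3-yl in place of 3-methoxy-5-(trifluoromethyl)phenyl on an aromatic carbon.

Going by the values given here, the only measured step at this same position is a 4.0-fold higher number from compound 1 to compound 3 (0.60 log units; beyond the scatter), where the ring on that carbon lost both the methoxy and the trifluoromethyl. Among the compounds with values here, the move to compound 4 keeps the methoxy, drops the trifluoromethyl and brings a ring nitrogen in, so it is a smaller structural move than the one to compound 3. Within the data shown here, the expectation in this assay is therefore a modest loss against compound 1, smaller than the step to compound 3, but likely beyond the scatter, because the one comparison available at this carbon, a 4.0-fold higher number from compound 1 to compound 3 (0.60 log units; beyond the scatter), went that way.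

Compound 4 is accordingly expected at 3500 nM (range 1200 nM to 10000 nM), an estimated step of a 2.5-fold higher number from compound 1 to compound 4 (0.40 log units; beyond the scatter).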

Compound 4, half-maximal effective concentration: 21000 nM
Beside the measured number, compound 4's estimate is 6.0-fold (0.78 log units) below it; the measured number lies above the stated range.
By their numbers in this assay, from the lowest: compound 1; then compounds 2 and 3 (each within the scatter of the next); then compound 4.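

Going by these compounds alone, the aromatic carbon next to the ring atom that bears a carboxy group tolerates change far less evenly than the one earlier step suggested: in (this assay) the move to 5-methoxypyridin-3-yl gives (a 15-fold higher number from compound 1 to compound 4 (1.18 log units; beyond the scatter)), a large step set against (a 4.0-fold higher number from compound 1 to compound 3 (0.60 log units; beyond the scatter)) for 2-methylphenyl. Keeping the methoxy therefore does not hold the value, and the group with neither methoxy nor a ring nitrogen still compares favourably, with (a 3.8-fold higher number from compound 3 to compound 4 (0.58 log units; beyond the scatter)). No measurement here accounts for this loss.

Compound 4 differs from compound 1 by the absence of trifluoromethyl and the presence of a ring nitrogen together, so the compounds shown do not apportion the step between these two changes. 3-Methoxyphenyl and 5-(trifluoromethyl)pyridin-3-yl at this carbon would separate them, and a 3-methoxy-5-(trifluoromethyl)phenyl ring carrying an added amine would test whether further substitution on the ring is accepted in this series.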